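A few compounds are considered here, and "the series" means these few. Any claim that something is new, unique, unknown or untested is made for them only; others in the source may bear on it.

Measured so far:
- compound 1, `Cn1c(=O)c(S(=O)(=O)c2ccc(F)cc2F)cc2cnc(Nc3ccc4[nH]c(C(=O)O)cc4c3)nc21`: 10000 nM
- compound 2, `Cn1c(=O)c(S(=O)(=O)c2ccc(OC(=O)CCCCC3SCC4NC(=O)NC43)cc2)cc2cnc(Nc3ccc4[nH]ccc4c3)nc21`: 150 nM

Compound 1 stands at the highest of the two numbers recorded in a functional assay on DU-145 cells (Homo sapiens) for inhibition, read by trypan blue exclusion, with a stated time of 72 h; on this read-out lower numbers stand for stronger inhibition and higher numbers for weaker inhibition. In this assay compound 1 gives 10000 nM, and compound 2 gives 150 nM; the two compounds differ in more than one place, so the pair is read only for what the two values show, and the gap between them lies beyond the scatter.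

Compound 3, `Cn1c(=O)c(S(=O)(=O)c2ccc(F)cc2F)cc2cnc(Nc3ccc4[nH]ncc4c3)nc21`, is not yet measured. Its relation to compound 1 is a single change: 1H-indazol-5-yl in place of 2-carboxy-1H-indol-5-yl on a nitrogen on an aromatic ring.

Among the compounds with values here, no step between measured compounds is available for this kind of change. Compound 2, which carries no carboxy group on its bicyclic amine, sits far lower than compound 1, and that is the only hint the data give. The expectation is that the step from compound 1 to compound 3 in this assay is downward and beyond the scatter, roughly a 20-fold lower number from compound 1 to compound 3 (1.30 log units; beyond the scatter). Compound 3 is estimated at 500 nM, with a range from 100 nM to 5000 nM.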

Compound 3, half-maximal inhibitory concentration: 30000 nM
For compound 3 the middle estimate is 60-fold (1.78 log units) below the measured one, and the stated range ends below it.
By their numbers in this assay, from the lowest: compound 2; then compound 1; then compound 3.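

On the nitrogen on an aromatic ring, with the rest of compound 1 unchanged, 1H-indazol-5-yl in place of 2-carboxy-1H-indol-5-yl gives in this assay a 3.0-fold higher number from compound 1 to compound 3 (0.48 log units; beyond the scatter), a modest step that lies beyond the scatter. Within the data shown here, on this core, then, removing the carboxy group as part of this exchange does not lower the number, and this is the first read-out of a change at this place; the exchange alters both the carboxy group and the five-membered ring, which now holds 2 hetero atoms, and this single step cannot separate the two. No measurement available here bears on what lies behind the step.

Still open, as far as these compounds go, is how a plain 1H-indol-5-yl group would read on the core of compound 1, and whether a methyl ester or a carboxamide in place of the carboxylic acid would move the number in either direction. Compound 2, at 150 nM, differs from both of the others in more than one place, so which of its features goes with that value remains unresolved.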